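The compounds below may be only part of what the source reports. "The series", "measured", "known", "first", "only" and "open" are said of these compounds alone.

Of the compounds shown here, three that share one core have been tested in a functional assay on DU-145 cells (Homo sapiens) for cytotoxicity, read by sulforhodamine B assay, with a stated time of 48 h; on this read-out lower numbers stand for stronger inhibition and higher numbers for weaker inhibition. In this test, compound 1 `COc1ccc(C2=NO[C@]3(C2)C(=O)O[C@@H]2[C@H]3CC[C@H](C)[C@]3(O)C=CC(=O)[C@@]23C)cc1` gives 20000 nM, compound 2 `C[C@H]1CC[C@@H]2[C@@H](OC(=O)[C@]23CC(c2ccc(Cl)cc2)=NO3)[C@]2(C)C(=O)C=C[C@@]12O` gives 43000 nM and compound 3 `C[C@H]1CC[C@@H]2[C@@H](OC(=O)[C@]23CC(c2ccc(O)cc2)=NO3)[C@]2(C)C(=O)C=C[C@@]12O` gives 93000 nM. Compound 3 thus has the highest number of the three and is the weakest inhibitor among them. Its two gaps are modest but beyond the scatter: a 4.7-fold higher number from compound 1 to compound 3 (0.67 log units; beyond the scatter) and a 2.2-fold higher number from compound 2 to compound 3 (0.34 log units; beyond the scatter). The third measured step, a 2.2-fold higher number from compound 1 to compound 2 (0.33 log units; beyond the scatter), is also modest.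

The next compound is compound 4 `C[C@H]1CC[C@@H]2[C@@H](OC(=O)[C@]23CC(c2ccccc2F)=NO3)[C@]2(C)C(=O)C=C[C@@]12O`, which has 2-fluorophenyl in place of 4-hydroxyphenyl on a carbon with a double bond to nitrogen. The steps to compound 3 bear most directly on this change, since each of them brought in the hydroxy group and raised the number. Removing that group is therefore expected to lower the number by a similarly modest amount. However, no measured compound carries fluoro or a 2-fluorophenyl group, so this rests on only three values. The step expected in this assay is a 2.3-fold lower number from compound 3 to compound 4 (0.37 log units; beyond the scatter). For compound 4 the estimated value is 40000 nM, with an expected range from 15000 nM to 100000 nM.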

Compound 4, half-maximal inhibitory concentration: 24000 nM
Estimate against measurement, compound 4: 1.7-fold (0.22 log units) above, within the range that was stated.
By their numbers in this assay, from the lowest: compounds 1, 4 and 2 (each within the scatter of the next, the first and the last beyond it); then compound 3.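

In this assay, the group on the carbon with a double bond to nitrogen of the five-membered ring was changed from 4-hydroxyphenyl to 2-fluorophenyl, giving a 3.9-fold lower number from compound 3 to compound 4 (0.59 log units; beyond the scatter) and the largest new step beyond the scatter. The other two new steps show no such separation: a 1.8-fold lower number from compound 2 to compound 4 (0.25 log units; within the scatter) and a 1.2-fold higher number from compound 1 to compound 4 (0.08 log units; within the scatter) are both within the scatter, so compound 4 cannot be ordered against compound 2 or compound 1. Among the four compounds, only compound 3 stands clear of compound 4, and it alone of the four carries a hydrogen-bond donor on this aromatic ring, although the step to compound 4 changes both the group on the ring and where it sits, so the two cannot be told apart here.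

The compounds shown offer no measured explanation for why the hydroxy compound gives the highest number. On these data alone, it remains open whether plain phenyl, 4-fluorophenyl, 2-hydroxyphenyl or a ring bearing an amine or a carboxylic acid would read with compound 3 or with compound 1, compound 2 and compound 4.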